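A few compounds are considered here, and "the series" means these few. Any claim that something is new, unique, unknown or untested is made for them only; others in the source may bear on it.

Compound 1 `ClCc1ccc(Cn2cnc3c(Cl)ncnc32)cc1` gives 1950 nM in a functional assay on HCT-15 cells (Homo sapiens) for cytotoxicity, read by sulforhodamine B assay, with a stated time of 48 h; a higher number here means a weaker inhibitor of growth, a lower number a stronger inhibitor of growth. Compound 2 `Nc1nc(Cl)c2ncn(Cc3ccc(CCl)cc3)c2n1` gives 4900 nM in this assay. Compound 3 `ClCc1ccccc1Cn1cnc2c(Cl)ncnc21` gives 2090 nM in this assay.

Compound 2 differs from compound 1 by one change, (amino in place of hydrogen on an aromatic carbon), and that change made the step of a 2.5-fold higher number from compound 1 to compound 2 (0.40 log units; beyond the scatter). Compound 4 `Nc1nc(Cl)c2ncn(Cc3ccccc3CCl)c2n1` carries the same change on the core of compound 3, (amino in place of hydrogen on an aromatic carbon); the place is described in the same words for both pairs, so it is the same change. How the cores of compound 1 and compound 3 differ is not broken down here, but their values in this assay lie within the scatter of each other. For compound 4 a step of similar size is therefore expected, a 2.4-fold higher number from compound 3 to compound 4 (0.38 log units; beyond the scatter), resting on the measured step of a 2.5-fold higher number from compound 1 to compound 2 (0.40 log units; beyond the scatter). Compound 4 is thus estimated at 5000 nM, with a range from 2500 nM to 10000 nM.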

Compound 4, concentration for 50% growth inhibition: 2700 nM
For compound 4 the middle estimate is 1.9-fold (0.27 log units) above the measured one, within the range that was stated.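

In this assay, putting amino in place of hydrogen gives a 1.3-fold higher number from compound 3 to compound 4 (0.11 log units; within the scatter), a step that cannot be told apart from no change. Set beside the earlier step, the two do not differ by more than repeated measurements allow: the same change on two cores in this assay, a 2.5-fold higher number (0.40 log units; beyond the scatter) from compound 1 to compound 2 and a 1.3-fold higher number (0.11 log units; within the scatter) from compound 3 to compound 4, 1.9-fold (0.29 log units) apart, within the scatter of two such steps. This fits the change carrying over between the two cores, but two pairs, one of them within the scatter, do not prove it or fix the size of the step.

The compounds shown leave open how a methyl or methoxy group would behave at the same place. They also leave open whether the step holds on cores other than those of compound 1 and compound 3.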